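Nitrophenyl Swapped for Trifluorophenyl in a Peptide-Like Inhibitor

The source may report more compounds than this note shows. Statements on the series, on what has been measured and on what is new or still open speak of the compounds shown alone.

Compound 1, `CC(C)[C@H](NC(=O)COc1cccc2ccccc12)C(=O)N[C@@H](CC(=O)O)C(=O)COc1ccccc1[N+](=O)[O-]`, carries a 2-nitrophenyl group on an oxygen on a saturated carbon. In a functional assay with Homo sapiens as the target (a higher number here means a weaker inhibitor, a lower number a stronger inhibitor), compound 1 gives 27700 nM, the highest of the three numbers at hand, although its gaps to both other compounds stay within the scatter. Compound 2, `CC(C)[C@H](NC(=O)COc1cccc2ccccc12)C(=O)N[C@@H](CC(=O)O)C(=O)COc1ccc(F)cc1F`, gives 17600 nM, and compound 3, `CC(C)[C@H](NC(=O)COc1cccc2ccccc12)C(=O)N[C@@H](CC(=O)O)C(=O)COc1cc(F)ccc1F`, gives 19700 nM. Compound 4, `CC(C)[C@H](NC(=O)COc1cccc2ccccc12)C(=O)N[C@@H](CC(=O)O)C(=O)COc1c(F)cc(F)cc1F`, has not yet been measured; it differs from compound 1 by 2,4,6-trifluorophenyl in place of 2-nitrophenyl on an oxygen on a saturated carbon. Two earlier changes at the very same place bear on this one: the step of a 1.6-fold lower number from compound 1 to compound 2 (0.20 log units; within the scatter) and the step of a 1.4-fold lower number from compound 1 to compound 3 (0.15 log units; within the scatter) each replaced the same 2-nitrophenyl with a fluorinated ring and moved the number only slightly downward, while a 1.1-fold higher number from compound 2 to compound 3 (0.05 log units; within the scatter) shows the two fluorinated rings side by side. With three small changes of the same kind behind it, no step beyond the scatter is expected for compound 4, at most a slight drift to a lower number. Compound 4 is therefore expected to give 19000 nM, between 9000 nM and 40000 nM, which is a step of a 1.5-fold lower number from compound 1 to compound 4 (0.16 log units; within the scatter).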

Compound 4, half-maximal inhibitory concentration: 14900 nM
For compound 4 the middle estimate is 1.3-fold (0.11 log units) above the measured one; the range from low to high includes it.
By their numbers in this assay, from the lowest: compounds 4, 2, 3 and 1 (each within the scatter of the next).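

In this assay, the full set of rings at this place on an oxygen on a saturated carbon now spans nitro, difluoro and trifluoro patterns, yet replacing 2-nitrophenyl with 2,4,6-trifluorophenyl still stays within the scatter (a 1.9-fold lower number from compound 1 to compound 4 (0.27 log units; within the scatter)). Adding one more fluoro in place of hydrogen on an aromatic carbon is also a step within the scatter (a 1.2-fold lower number from compound 2 to compound 4 (0.07 log units; within the scatter)), as is the exchange of the 2,5-difluorophenyl ring for the trifluorinated one (a 1.3-fold lower number from compound 3 to compound 4 (0.12 log units; within the scatter)). No measured evidence is available to explain these numbers.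

Going by these compounds, what a plain phenyl, a chlorophenyl or a non-aromatic cyclohexyl group would do at this place stays open. Also open, on these data alone, is whether any group here can move the number beyond the scatter.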